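Swapping the chain end of compound 2 for a dimethylcarbamoyl group

The source may hold more compounds than are shown below. What is called first, only, known or untested is meant among the compounds shown, and "the series" means these compounds.

Measured so far:
- compound 1, `CCc1cc(C(C)=O)c(O)cc1OCCCCCCCC(C)(C)C#N`, in an assay on isolated protein for inhibition of leukotriene B4 receptor 1 (Homo sapiens), tested at 10 uM (on this read-out lower numbers stand for less inhibition and higher numbers for more inhibition at the one concentration tested (going by the name of the read-out)), compound 1 gives 66%
- compound 2, `CCc1cc(C(C)=O)c(O)cc1OCCCCCC[S+](C)[O-]`, in this assay compound 2 gives 92%

Compound 2 stands highest of the two numbers shown; its nearest neighbour is compound 1, and the step of a number 26 percentage points higher from compound 1 to compound 2 (beyond the scatter) lies beyond the scatter. Compound 3, `CCc1cc(C(C)=O)c(O)cc1OCCCCCCC(=O)N(C)C`, has not yet been measured. It differs from compound 2 in this way: a group of 5 heavy atoms (3 carbon, 1 nitrogen, 1 oxygen; no ring) in place of a group of 3 heavy atoms (1 carbon, 1 oxygen, 1 sulfur; no ring), on a saturated chain carbon, six bonds along the chain from an oxygen on an aromatic ring. Going by the values given here, only one measured step bears on the question, a number 26 percentage points higher from compound 1 to compound 2 (beyond the scatter), and it concerns a different pair of chain-end groups, so it gives no direct guide to the present exchange. Compound 2 already sits near the top of the read-out, so a step of a number 14 percentage points lower from compound 2 to compound 3 (beyond the scatter) is expected to be small or downward rather than upward. Compound 3 is therefore estimated at 78%, within a range from 52% to 95%.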

Compound 3, a percentage reported as inhibition, at one concentration (the size of the read-out at that concentration, not a potency): 100%
Compound 3: middle estimate off by 22 percentage points, on the low side, outside the stated range (above it).
By their numbers in this assay, from the lowest: compound 1; then compounds 2 and 3 (each within the scatter of the next).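

In this assay, the dimethylcarbamoyl group on a saturated chain carbon, six bonds along the chain from an oxygen on an aromatic ring, gives a number 8 percentage points higher from compound 2 to compound 3 (within the scatter) in place of the sulfur-bearing chain end. This position therefore takes a chain end of 5 heavy atoms in place of 3 with no difference that can be told from the scatter. Against the 2-cyano-2-methylpropyl end, the dimethylcarbamoyl group gives a number 34 percentage points higher from compound 1 to compound 3 (beyond the scatter) on this read-out. Nothing at hand explains these results.

As far as these compounds go, whether a carboxylic acid, a primary amine or a longer chain ending in the dimethylcarbamoyl group would hold this level remains open. A read-out at one concentration also leaves open whether compound 2 and compound 3 differ in potency.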